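A Halogen Shift on the Amide Arm of Compound 1

The source may report more compounds than this note shows. Statements on the series, on what has been measured and on what is new or still open speak of the compounds shown alone.

For the measured compounds named here, compound 1 `CCOC(=O)C1=Cc2ccccc2OC1(OCc1cn(CC(=O)Nc2ccccc2F)nn1)C(F)(F)F` is the only member of this small set to yield a number: in a functional assay on MCF7 cells (Homo sapiens) for inhibition, read by MTT assay, with a stated time of 24 h (on this read-out lower numbers stand for stronger inhibition and higher numbers for weaker inhibition), compound 1 gives 42100 nM. Compound 2 `CCOC(=O)C1=Cc2ccccc2OC1(OCc1cc(-c2ccc(Br)cc2)no1)C(F)(F)F` reaches only a limit of the assay, > 150000 nM, in this assay. Compound 3 `CCOC(=O)C1=Cc2ccccc2OC1(OCc1cc(-c2ccc([N+](=O)[O-])cc2)no1)C(F)(F)F` likewise stops at a limit, > 150000 nM. Going by the values given here, the single measured step, a step that the two limits leave unreadable from compound 2 to compound 3, cannot be read because the limit of > 150000 nM in this assay, at which 2 of the 3 values shown sit, holds both of its ends, and it concerns a different arm of the shared core. Compound 4 `CCOC(=O)C1=Cc2ccccc2OC1(OCc1cn(CC(=O)Nc2cccc(Cl)c2)nn1)C(F)(F)F` differs from compound 1 in one place: 3-chlorophenyl in place of 2-fluorophenyl on an amide-type nitrogen. Among the compounds with values here, no measured step speaks to this change, so the expected step from compound 1 to compound 4, a 1.1-fold higher number from compound 1 to compound 4 (0.03 log units; within the scatter), is none beyond the scatter. Compound 4 is therefore estimated at 45000 nM, within 15000 nM to 150000 nM.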

Compound 4, half-maximal inhibitory concentration: 11600 nM
Beside the measured number, compound 4's estimate is 3.9-fold (0.59 log units) above it, outside the stated range (below it).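

In this assay, the aryl group on the amide-type nitrogen proves able to move the read-out: 3-chlorophenyl in place of 2-fluorophenyl gives a 3.6-fold lower number from compound 1 to compound 4 (0.56 log units; beyond the scatter). For the compounds shown here, this is the first step in the set that can be read, and it places this position, not the arm carrying the limits, as the one with a measured response. Nothing shown accounts for the step.

The halogen and its place on the ring change together in this swap, and the compounds shown do not separate the two. As far as these compounds go, how 3-fluorophenyl, 2-chlorophenyl, or a ring carrying an amine or a carboxylic acid would read at this position stays open.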